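Aryl swap on the triazole nitrogen, judged against limits

The source may hold more compounds than are shown below. What is called first, only, known or untested is meant among the compounds shown, and "the series" means these compounds.

Compound 3 `CCc1cccc(CC)c1-n1nncc1CN1C(=O)C2(C(C#N)=C(N)Oc3c(N)cc4nc5ccccc5nc4c32)c2ccccc21` stands at a limit in an ADME assay on L02 cells (Homo sapiens) for antiproliferative activity, read by MTT assay, with a stated time of 48 h (a higher number here means a weaker inhibitor, a lower number a stronger inhibitor), where it gives > 50000 nM; that reading is a limit, not a number. Compound 1 `CCOc1ccccc1-n1nncc1CN1C(=O)C2(C(C#N)=C(N)Oc3c(N)cc4nc5ccccc5nc4c32)c2ccccc21` likewise gives > 50000 nM, a limit. Compound 2 `CCc1cccc(C)c1-n1nncc1CN1C(=O)C2(C(C#N)=C(N)Oc3c(N)cc4nc5ccccc5nc4c32)c2ccccc21` gives > 50000 nM, again a limit. All three shown values therefore rest at the limit of > 50000 nM in this assay, at which 3 of the 3 values shown sit. The change to compound 4 `COc1cc(-n2nncc2CN2C(=O)C3(C(C#N)=C(N)Oc4c(N)cc5nc6ccccc6nc5c43)c3ccccc32)c(OC)cc1Cl` is 4-chloro-2,5-dimethoxyphenyl in place of 2,6-diethylphenyl on an aromatic nitrogen. Within the data shown here, the steps that bear on it are a step that the two limits leave unreadable from compound 1 to compound 2, a step that the two limits leave unreadable from compound 1 to compound 3 and a step that the two limits leave unreadable from compound 2 to compound 3; none of them has a readable size, so no direction can be taken from them, and no step beyond the scatter is expected in this assay. Compound 4 is accordingly expected to remain at the limit, estimated at 50000 nM with a range from 20000 nM to 120000 nM. The expected step is a number no higher from compound 3 to compound 4 (the limit leaves the size open).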

Compound 4, half-maximal inhibitory concentration: > 50000 nM
Compound 4: only a limit was reported; the forecaster's own chance of this, stated with the estimate: 80%; the middle value lies on the limit itself.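

Like compounds 1, 2 and 3, compound 4 stands at a limit, so no step from any of them to compound 4 can be read. The compounds shown leave open whether any aryl group on the aromatic nitrogen gives a readable value in this assay.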